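The source may report more compounds than this note shows. Statements on the series, on what has been measured and on what is new or still open speak of the compounds shown alone.

Three related compounds have been measured in a physicochemical assay for solubility, read by HPLC, in phosphate buffer, measured as kinetic solubility, at pH 7.4; a higher number here means a more soluble compound, a lower number a less soluble compound. There, compound 1 `CCC(=O)c1cc(-c2ccccc2Cl)n(-c2ccc(S(N)(=O)=O)cc2)c1C` gives 38200 nM, compound 2 `CCOC(=O)c1cc(-c2ccc(OC)cc2)n(-c2ccc(S(N)(=O)=O)cc2)c1C` gives 16100 nM, and compound 3 `CCOC(=O)c1cc(-c2cccc(Cl)c2)n(-c2ccc(S(N)(=O)=O)cc2)c1C` gives 9200 nM. Compound 3 thus stands within the scatter of compound 2, and both numbers lie clearly under that of compound 1.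

The next compound, compound 4 `CCOC(=O)c1cc(-c2ccccc2Cl)n(-c2ccc(S(N)(=O)=O)cc2)c1C`, has not yet been measured. It differs from compound 3 as follows: 2-chlorophenyl in place of 3-chlorophenyl on an aromatic carbon. In words, a 2-chlorophenyl stands in place of a 3-chlorophenyl on an aromatic carbon next to the ring nitrogen, so the two have the same atoms, joined differently.

Going by the values given here, the only measured step at this place is a 1.8-fold lower number from compound 2 to compound 3 (0.24 log units; within the scatter), which stays within the scatter, although it exchanges a 4-methoxyphenyl and not one chlorophenyl for another. Compound 1 already carries the 2-chlorophenyl and gives 38200 nM, but it lacks the ethoxycarbonyl group, so its number offers only a loose hint. Among the compounds with values here, no measured pair isolates this change.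

In this assay, a small upward move is therefore expected, with nothing clearly beyond the scatter. The estimated step is a 1.7-fold higher number from compound 3 to compound 4 (0.24 log units; within the scatter). For compound 4 the expected value is 16000 nM, with an estimated range of 7000 nM to 36000 nM.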

Compound 4, solubility: 13700 nM
Beside the measured number, compound 4's estimate is 1.2-fold (0.07 log units) above it; the measured number falls inside the stated range.
By their numbers in this assay, from the lowest: compounds 3, 4 and 2 (each within the scatter of the next); then compound 1.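

In this assay, going by these compounds alone, the 2-chlorophenyl in place of 3-chlorophenyl on the aromatic carbon next to the ring nitrogen gives a 1.5-fold higher number from compound 3 to compound 4 (0.17 log units; within the scatter), and the 2-chlorophenyl in place of 4-methoxyphenyl at this place gives a 1.2-fold lower number from compound 2 to compound 4 (0.07 log units; within the scatter), so the first pair to isolate the chlorine's position, and the three groups compared here with the ethoxycarbonyl group held in common, show no step beyond the scatter. The only step beyond the scatter among these new pairs lies at the other place, where ethoxy in place of ethyl on a carbonyl carbon, with the 2-chlorophenyl held in common, gives a 2.8-fold lower number from compound 1 to compound 4 (0.45 log units; beyond the scatter), a modest step. No measurement at hand offers an explanation for any of these steps.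

Going by these compounds, that step on the carbonyl carbon rests on this single pair, so it remains open whether it would recur with 3-chlorophenyl or 4-methoxyphenyl on the aromatic carbon next to the ring nitrogen. On these data alone, it also remains open how a carboxylic acid in place of the ethoxycarbonyl group, or an amine on the phenyl ring at the aromatic carbon, would read in this assay.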